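A Single Methyl on the Shared Core: What to Expect

The source may hold more compounds than are shown below. What is called first, only, known or untested is meant among the compounds shown, and "the series" means these compounds.

Measured so far:
Compound 1, `NCC(=O)NCc1nncn1-c1ccc(Cl)cc1C(=O)c1ccccc1`: in a functional assay on the whole organism with Mus musculus as the target, in the rotarod test (a lower number here means that less compound is needed, a higher number that more compound is needed for the effect), compound 1 gives 11.8 mg/kg.
Compound 2, `CN(C(=O)CNC(=O)CN)c1ccc(Cl)cc1C(=O)c1ccccc1Cl`: in this assay compound 2 gives 35.4 mg/kg.

Of these two, compound 1 has the lower number in this assay, so less of it is needed for the same effect; the gap to compound 2 lies beyond the usual scatter. For the measured compounds named here, compound 1 and compound 2 differ in several places at once, so their two values show only that compound 1 needs less, not why.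

The unmeasured compound 3, `Cc1nnc(CNC(=O)CN)n1-c1ccc(Cl)cc1C(=O)c1ccccc1`, differs from compound 1 in one place only: methyl in place of hydrogen on an aromatic carbon. A change this small, on the shared core, gives no reason to expect a shift beyond the scatter in this assay, in either direction. The step expected from compound 1 to compound 3 is therefore a 1.0-fold higher number from compound 1 to compound 3 (0.01 log units; within the scatter). Compound 3 is thus estimated to give about 12 mg/kg in this assay, with a likely range from 5 mg/kg to 30 mg/kg.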

Compound 3, dose for half-maximal effect: 3.94 mg/kg
Compound 3: middle estimate off by 3.0-fold (0.48 log units), on the high side; measured number outside the range, below it.
By their numbers in this assay, from the lowest: compound 3; then compound 1; then compound 2.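

The aromatic carbon between two ring nitrogen atoms turns out to be sensitive: methyl in place of hydrogen there gives a 3.0-fold lower number from compound 1 to compound 3 (0.48 log units; beyond the scatter) in this assay. So a change of a single heavy atom, with no hydrogen-bond donors or acceptors and no net charge, is enough to reduce the dose needed for the effect by more than the usual scatter. No available evidence bears on why this happens.

With only hydrogen and methyl shown at this carbon, it remains open whether a longer chain such as ethyl, or an amine, would lower the number further or raise it again. From the compounds shown here alone, it also remains open whether methyl at this carbon would give a similar step with a different group in place of the (((aminomethyl)carbonyl)amino)methyl group.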